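From chloro to nitro in a cytotoxicity test

A few compounds are considered here, and "the series" means these few. Any claim that something is new, unique, unknown or untested is made for them only; others in the source may bear on it.

- compound 1 `Clc1ccc(-c2c[nH]cc2C(c2ccc(Cl)cc2Cl)n2ccnc2)cc1` gives 9610 nM 
- compound 2 `Clc1ccc(-c2c[nH]cc2C(c2ccc(Cl)cc2)n2ccnc2)cc1` gives 4830 nM 

Both numbers come from an ADME assay on L6 cells (Rattus norvegicus) for cytotoxicity, read by fluorescence and resazurin assay, with a stated time of 72 h (on this read-out lower numbers stand for higher toxicity in this test and higher numbers for lower toxicity in this test), and they are the only two measured so far. Compound 1 has a single neighbour on this scale, compound 2, and the two lie within the usual scatter of each other, so neither can be ranked above the other.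

The next compound, compound 3 `O=[N+]([O-])c1ccc(-c2c[nH]cc2C(c2ccc(Cl)cc2Cl)n2ccnc2)cc1`, keeps the core of compound 1 and exchanges one group: nitro in place of chloro on an aromatic carbon (nitro in place of chloro on an aromatic carbon, that is, 4-chlorophenyl to 4-nitrophenyl). Among the compounds with values here, the only measured step is a 2.0-fold lower number from compound 1 to compound 2 (0.30 log units; within the scatter) and it concerns a different chloro, leaving this one untouched. Within the data shown here, no measured compound carries a nitro group, so the data point in no clear direction and only a weak guide is available in this assay for this change. The expected outcome is a 1.4-fold lower number from compound 1 to compound 3 (0.14 log units; within the scatter) and this estimated step stays within the scatter, although the margin must be wide. Compound 3 is therefore estimated at 7000 nM (expected range 2500 nM to 20000 nM).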

Compound 3, half-maximal cytotoxic concentration: 16900 nM
Compound 3: the middle estimate sits 2.4-fold (0.38 log units) below what was measured; the range from low to high includes it.
By their numbers in this assay, from the lowest: compounds 2, 1 and 3 (each within the scatter of the next, the first and the last beyond it).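

Exchanging chloro for nitro on this aromatic carbon, para to a large group, gives a 1.8-fold higher number from compound 1 to compound 3 (0.25 log units; within the scatter) in this assay. Within the data shown here, this is the first reading at this place on the ring, and the earlier step concerned a different chloro. The reading shows that going from 4-chlorophenyl to 4-nitrophenyl, with three heavy atoms entering where one leaves and two hydrogen-bond acceptors added, produces no difference that can be told apart from the ordinary spread of repeated measurements. No measurement shown here offers an explanation for this result.

What the compounds shown leave open is whether this tolerance holds for groups of a different kind at the same place, such as an amine or a carboxylic acid, where a step beyond the scatter would be needed before any ranking could be made. As far as these compounds go, it is also open whether the same exchange of chloro for nitro would give a similar result on the core of compound 2, which lacks the other chloro kept in compound 1 and compound 3.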